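Removing the methoxy group from a thiocyanate-bearing core

A few compounds are considered here, and "the series" means these few. Any claim that something is new, unique, unknown or untested is made for them only; others in the source may bear on it.

This account concerns a small set of fused bicyclic compounds tested in a functional assay on cells (Cancer cell lines, Homo sapiens) for inhibition; a higher number here means a weaker inhibitor of growth, a lower number a stronger inhibitor of growth. Compound 1 `COc1ccc(-c2nc3sc(Cc4ccccc4)nn3c2SC#N)cc1` gives 56200 nM in this assay. Compound 2 `O=Cc1c(-c2ccc([N+](=O)[O-])cc2)nc2sc(Cc3ccccc3)nn12` gives 39800 nM, and compound 3 `O=Cc1c(-c2ccc(F)cc2)nc2sc(CCC3CCCCC3)nn12` gives 97700 nM. Compound 1 stands second highest of the three numbers, but its gap to compound 2 and its gap to compound 3 both fall within the usual scatter, so the three values cannot be told apart in this assay.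

The step under consideration leads from compound 1 to compound 4 `N#CSc1c(-c2ccccc2)nc2sc(Cc3ccccc3)nn12`, which has not yet been measured in this assay. The change is hydrogen in place of methoxy on an aromatic carbon: hydrogen replaces methoxy on an aromatic carbon of a six-membered aromatic ring of carbon only. Among the compounds with values here, since no measured pair in this set shares this change, there is no step to lean on, and the three measured numbers all sit close together.

Compound 4 is therefore expected to show a step of a 1.1-fold higher number from compound 1 to compound 4 (0.03 log units; within the scatter), that is, nothing beyond the scatter. The estimate for compound 4 is 60000 nM, with a range from 25000 nM to 150000 nM.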

Compound 4, concentration for total growth inhibition: 79400 nM
Compound 4: middle estimate off by 1.3-fold (0.12 log units), on the low side; measured number inside the range.
By their numbers in this assay, from the lowest: compounds 2, 1, 4 and 3 (each within the scatter of the next, the first and the last beyond it).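

In this assay, within the data shown here, replacing 4-methoxyphenyl with phenyl gives a 1.4-fold higher number from compound 1 to compound 4 (0.15 log units; within the scatter) and provides the first comparison in this set between compounds that differ in one place. It shows that, on this thiocyanate-bearing core, methoxy para to a large group can give way to hydrogen without a change that can be told from the scatter, so the methoxy group is not required for the level of growth inhibition seen with compound 1. No measurement is available that could explain this result.

On these data alone, whether an amine or a carboxylic acid at this same place on the ring would move the number beyond the scatter remains open. Also open, as far as these compounds go, is whether the same change from methoxy to hydrogen would give a similar result with an aldehyde in place of the thiocyanate.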